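Carbamate ester swap on a shared core: ethyl to oxolanyl

The compounds below may be only part of what the source reports. "The series", "measured", "known", "first", "only" and "open" are said of these compounds alone.

Of the compounds shown here, two sharing one core have been measured so far in an assay on CHO-K1 cells for displacement of a labelled ligand from prostaglandin E2 receptor EP1 subtype (Homo sapiens); on this read-out lower numbers stand for stronger inhibition and higher numbers for weaker inhibition. Compound 1, `Cc1cc(C(=O)Nc2ccccn2)nn1Cc1cc(Cl)ccc1OCc1ccccc1`, gives 126 nM. Compound 2, `CCOC(=O)Nc1cc(C)n(Cc2cc(Cl)ccc2OCc2ccccc2)n1`, gives 79.4 nM. Among the compounds with values here, on these numbers compound 2 has the lowest value of the two, yet its only neighbour, compound 1, sits within the scatter, as the step of a 1.6-fold lower number from compound 1 to compound 2 (0.20 log units; within the scatter) shows, so no order between them can be claimed.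

Compound 3, `Cc1cc(NC(=O)O[C@H]2CCOC2)nn1Cc1cc(Cl)ccc1OCc1ccccc1`, is not yet measured. It differs from compound 2 in one place: oxolan-3-yl in place of ethyl on an oxygen next to a carbonyl group. Within the data shown here, no measured step touches this part of the molecule; the single step from compound 1 to compound 2 altered a different group and stayed within the scatter. There is therefore no basis for expecting a shift beyond the scatter in this assay in either direction.

For compound 3 the expected value is 80 nM, with a likely range from 30 nM to 250 nM, which amounts to an expected step of a 1.0-fold higher number from compound 2 to compound 3 (0.00 log units; within the scatter).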

Compound 3, half-maximal inhibitory concentration in the prostaglandin E2 receptor EP1 subtype assay: 79.4 nM
Compound 3: middle estimate off by 1.0-fold (0.00 log units), on the high side; measured number inside the range.
By their numbers in the prostaglandin E2 receptor EP1 subtype assay, from the lowest: compounds 2, 3 and 1 (each within the scatter of the next).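

Within the data shown here, this is the first change at the oxygen next to a carbonyl group, and it shows that ethyl can give way to the ring-bearing oxolan-3-yl with no readable effect in the prostaglandin E2 receptor EP1 subtype assay, the step being no change at the digits printed from compound 2 to compound 3 (within the scatter), while the comparison with the amide-bearing compound gives a 1.6-fold lower number from compound 1 to compound 3 (0.20 log units; within the scatter). The same swap does register in another measurement, since in a physicochemical assay for lipophilicity, at pH 7.4 (on this read-out higher numbers stand for higher lipophilicity and lower numbers for lower lipophilicity), the step is a number at least 1.00 log units lower from compound 2 to compound 3 (beyond the scatter), with compound 3 at 2.7. In the physicochemical assay compound 2 gives > 3.7, which is a limit of the assay and not a number, so the step has no exact size: the limit of > 3.7 in the physicochemical assay, at which 1 of the 2 values shown sits.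

Among these compounds, only two groups have been seen on this oxygen, so it remains open whether the flat result in the prostaglandin E2 receptor EP1 subtype assay would hold for a longer chain, an amine or a carboxylic acid placed there. Compound 3 also carries oxolan-3-yl with one defined stereocentre, which leaves open how its mirror-image form would read in either measurement.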